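Pyridyl replacement on the benzyl arm of compound 2

This account rests on a few compounds, and the source may have more. Where it says the series, first, only, none or still open, it means among the compounds named here.

Compound 1 `Cc1ccccc1Nc1ncnn1-c1cccc(Cl)c1Cl`: 240 nM
Compound 2 `Clc1cccc(-n2ncnc2NCc2ccccc2)c1Cl`: 209 nM
Compound 3 `CCOc1ccccc1CNc1ncnn1-c1cccc(Cl)c1Cl`: 490 nM

The three measured compounds share a core carrying the dichlorophenyl group and differ only in the group attached to the ring nitrogen. In a functional assay for antagonist activity at P2X purinoceptor 7 (Rattus norvegicus), read by FLIPR and calcium flux (on this read-out higher numbers stand for weaker inhibition and lower numbers for stronger inhibition), compound 2 gives the lowest of the three numbers, though its gap to compound 1 is small: a 1.1-fold lower number from compound 1 to compound 2 (0.06 log units; within the scatter). Adding an ethoxy group to the benzyl ring did cost something, as a 2.3-fold higher number from compound 2 to compound 3 (0.37 log units; beyond the scatter) shows.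

Compound 4 `Cc1ncccc1CNc1ncnn1-c1cccc(Cl)c1Cl` is not yet measured. It differs from compound 2 in one place: 2-methylpyridin-3-yl in place of phenyl on a saturated chain carbon bound to a nitrogen on an aromatic ring. The benzyl arm itself is kept, so the change is one within the terminal ring rather than a change of the arm.

Neither measured step touches a ring nitrogen directly. The step from compound 2 to compound 3 shows that a substituent on the benzyl ring can weaken inhibition modestly, while the step from compound 1 to compound 2 shows the arm tolerates a different aromatic group with little change. On balance a modest weakening, or none beyond the scatter, is expected for compound 4, amounting to a 1.5-fold higher number from compound 2 to compound 4 (0.19 log units; within the scatter). Compound 4 is therefore estimated to give 320 nM in this assay, with a range from 130 nM to 800 nM.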

Compound 4, half-maximal inhibitory concentration: 295 nM
For compound 4 the middle estimate is 1.1-fold (0.04 log units) above the measured one; low and high end bracket the measured number.
By their numbers in this assay, from the lowest: compounds 2, 1, 4 and 3 (each within the scatter of the next, the first and the last beyond it).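

In this assay, the step to the 2-methylpyridin-3-yl group gives a 1.4-fold higher number from compound 2 to compound 4 (0.15 log units; within the scatter), so this position on the saturated chain carbon accepts a terminal ring with a nitrogen in it and a methyl group on it with no change that can be told from scatter. The earlier steps shown here had not tested a ring hetero atom here: the ethoxy step, a 2.3-fold higher number from compound 2 to compound 3 (0.37 log units; beyond the scatter), changed a substituent on an all-carbon ring and went beyond the scatter, whereas this change adds a hydrogen-bond acceptor to the terminal ring and stays within it. Nothing available explains why the ethoxy group and the 2-methylpyridin-3-yl group read differently against the scatter.

On these data alone, the methyl group and the ring nitrogen enter together, so what each contributes stays open, and an unsubstituted pyridin-3-yl group on the same arm would separate the two. Also open, as far as these compounds go, is how this read-out would respond to an amine or a carboxylic acid on the terminal ring, or to a longer chain in the arm.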